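The compounds below may be only part of what the source reports. "The series", "measured", "known", "first", "only" and "open" are said of these compounds alone.

Measured so far:
compound 1, `CCOc1ccc2nc(NC(=O)COc3ccc4cc(/C=C5/SC(=O)NC5=O)ccc4c3)sc2c1` — 17000 nM
compound 2, `Cc1cc(Br)ccc1NC(=O)COc1ccc2cc(/C=C3/SC(=O)NC3=O)ccc2c1` — 7400 nM

Both compounds share one core and differ only in the group carried on the amide-type nitrogen. In an assay on isolated protein for inhibition of histone deacetylase 8 (Homo sapiens), with a stated time of 1 h (a higher number here means a weaker inhibitor, a lower number a stronger inhibitor), compound 1 gives 17000 nM, and compound 2 gives 7400 nM, the lowest of the two numbers. The gap between them lies beyond the usual scatter, so compound 2 is the stronger inhibitor of the pair. Among the measured compounds shown here, no step between measured compounds that differ in a single place is available, so nothing measured fixes how much a change on the amide-type nitrogen moves the number.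

Compound 3, `O=C(COc1ccc2cc(/C=C3/SC(=O)NC3=O)ccc2c1)Nc1ccc(Br)c(Br)c1`, is the next compound in this series. (3,4-dibromophenyl in place of 4-bromo-2-methylphenyl on an amide-type nitrogen). The entering group is of like size to the one it replaces and carries no donor or acceptor, as before. For the measured compounds named here, with no measured step to lean on, the expected step of a 1.2-fold lower number from compound 2 to compound 3 (0.09 log units; within the scatter) is small and within the scatter, with a slight lean toward a lower number. Compound 3 is expected to give 6000 nM in this assay, with a range from 2500 nM to 15000 nM.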

Compound 3, half-maximal inhibitory concentration: > 50000 nM
Compound 3 gave a limit, no number; the forecaster's own chance of this, stated with the estimate: 5%; middle value at least 8.3-fold (0.92 log units) from the limit.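

In this assay compound 3 gives > 50000 nM, which is a limit of the assay and not a number. Among the compounds shown here, replacing 4-bromo-2-methylphenyl with 3,4-dibromophenyl on the amide-type nitrogen gives an at least 6.7-fold higher number from compound 2 to compound 3 (0.82 log units; beyond the scatter), the first single-place step, and it shows that this position is not indifferent to the choice of aryl group: the two groups match in heavy-atom count, carry no hydrogen-bond donors or acceptors and have no net charge, yet the step lies beyond the scatter. Its full size remains unfixed, and the step can be read only as a minimum: the limit of > 50000 nM in this assay, at which 1 of the 3 values shown sits.

The compounds shown leave open whether the step follows the removal of the methyl, the addition of the second bromine or the two together, as both alterations occur in this single change. Also open, on these data alone, is how the number responds on the same nitrogen to a phenyl carrying a single bromine, or to an aminophenyl or carboxyphenyl group, any of which would give this position a further single-place comparison.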